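Adding a Methyl on a Chain Carbon Bound to Nitrogen

This account rests on a few compounds, and the source may have more. Where it says the series, first, only, none or still open, it means among the compounds named here.

The measured compounds:
compound 1, `Cn1nc(-c2ccnc(Nc3ccc(S(N)(=O)=O)cc3)n2)c2ccccc21`, 2280 nM
compound 2, `Cn1nc(-c2ccnc(Nc3cccc(S(N)(=O)=O)c3)n2)c2ccccc21`, 1980 nM
compound 3, `CCn1nc(-c2ccnc(Nc3ccc(S(N)(=O)=O)cc3)n2)c2ccccc21`, 2050 nM

These three compounds were tested in a functional assay on HCT-116 cells (Homo sapiens) for antiproliferative activity, read by MTT assay, with a stated time of 72 h; a higher number here means a weaker inhibitor of growth, a lower number a stronger inhibitor of growth. Compound 1 gives 2280 nM, compound 2 gives 1980 nM and compound 3 gives 2050 nM; all three numbers lie within the usual scatter of one another, so no order among them can be claimed.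

Compound 1 and compound 2 have the same atoms joined differently; the difference between the two cores is not broken down here. Compound 3 differs from compound 1 by methyl in place of hydrogen on a saturated chain carbon bound to an aromatic nitrogen, and this change made a 1.1-fold lower number from compound 1 to compound 3 (0.05 log units; within the scatter).

Compound 4, `CCn1nc(-c2ccnc(Nc3cccc(S(N)(=O)=O)c3)n2)c2ccccc21`, has not yet been measured. It differs from compound 2 by methyl in place of hydrogen on a saturated chain carbon bound to an aromatic nitrogen, the same change, at the same place, as that from compound 1 to compound 3. Because a 1.1-fold lower number from compound 1 to compound 3 (0.05 log units; within the scatter), compound 4 is expected to show a step of about a 1.1-fold lower number from compound 2 to compound 4 (0.04 log units; within the scatter) in this assay. The estimate for compound 4 is 1800 nM, with a range from 900 nM to 3600 nM.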

Compound 4, concentration for 50% growth inhibition: 9010 nM
Compound 4: middle estimate off by 5.0-fold (0.70 log units), on the low side, and the stated range ends below it.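

In this assay, putting methyl in place of hydrogen on a saturated chain carbon bound to an aromatic nitrogen gave a 4.6-fold higher number from compound 2 to compound 4 (0.66 log units; beyond the scatter), which makes compound 4 a weaker inhibitor of growth than compound 2. The same change therefore did not carry over unchanged from the core of compound 1 to the core of compound 2: the same change on two cores in this assay, a 1.1-fold lower number (0.05 log units; within the scatter) from compound 1 to compound 3 and a 4.6-fold higher number (0.66 log units; beyond the scatter) from compound 2 to compound 4, 5.1-fold (0.70 log units) apart, beyond the scatter of two such steps This shows that the size of the step depends on the core for these two pairs, so a step read on one of these cores is a poor guide to the other, but it does not show why the two cores differ or how the change would behave on any other core in the series.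

A propyl chain in the same place could show whether the number keeps rising on the core of compound 2 while staying level on the core of compound 1. A chain ending in an amine or a carboxylic acid remains an open case on both cores.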